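Furan-3-yl Replaces 2-Methylphenyl on the Dienone Chain

This account rests on a few compounds, and the source may have more. Where it says the series, first, only, none or still open, it means among the compounds named here.

Compound 3 `CC1=C(/C=C/C(=O)/C=C/c2ccccc2C)C(C)(C)CCC1` gives 41000 nM in a functional assay on Hep cells (Homo sapiens) for cytotoxicity, read by sulforhodamine B assay, with a stated time of 48 h (a lower number here means a stronger inhibitor, a higher number a weaker inhibitor), the highest of the three numbers, though its gap to compound 2 stays within the scatter; compound 2 `CC1=C(/C=C/C(=O)/C=C/c2ccccc2F)C(C)(C)CCC1` gives 23600 nM and compound 1 `CC1=C(/C=C/C(=O)/C=C/c2ccccc2Br)C(C)(C)CCC1` gives 16300 nM. The measured steps are small: a 1.4-fold higher number from compound 1 to compound 2 (0.16 log units; within the scatter), a 1.7-fold higher number from compound 2 to compound 3 (0.24 log units; within the scatter) and a 2.5-fold higher number from compound 1 to compound 3 (0.40 log units; beyond the scatter). Compound 4 `CC1=C(/C=C/C(=O)/C=C/c2ccoc2)C(C)(C)CCC1` carries furan-3-yl in place of 2-methylphenyl on a double-bonded chain carbon bound to a double-bonded chain carbon. Within the data shown here, none of the measured steps exchanges the six-membered ring itself; they only vary its substituent, so they bear on this change weakly and show only modest movement in this assay. A step in either direction beyond the scatter cannot be excluded, but none is clearly indicated. Compound 4 is therefore expected near 30000 nM, within a range from 8000 nM to 100000 nM. This amounts to an expected step of a 1.4-fold lower number from compound 3 to compound 4 (0.14 log units; within the scatter).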

Compound 4, half-maximal inhibitory concentration: > 100000 nM
Compound 4 gave a limit, no number (the forecaster's own chance of this, stated with the estimate: 25%); middle value at least 3.3-fold (0.52 log units) away from the limit.
By their numbers in this assay, from the lowest: compounds 1, 2 and 3 (each within the scatter of the next, the first and the last beyond it). At a limit, above all of these: compound 4.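

The earlier compounds shown here varied only the substituent on the six-membered aromatic ring, whereas compound 4 replaces that ring itself with furan-3-yl. In this assay compound 4 gives > 100000 nM, which is a limit of the assay and not a number. All three steps to it lie beyond the scatter, so this place responds to exchange of the ring: an at least 2.4-fold higher number from compound 3 to compound 4 (0.38 log units; beyond the scatter), an at least 4.2-fold higher number from compound 2 to compound 4 (0.62 log units; beyond the scatter) and an at least 6.1-fold higher number from compound 1 to compound 4 (0.78 log units; beyond the scatter).

The full size of these steps cannot be read from a limit. The compounds shown also leave open whether the ring oxygen, the smaller ring or the lost substituent matters, and how an unsubstituted phenyl or a thiophen-3-yl would compare.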